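A few compounds are considered here, and "the series" means these few. Any claim that something is new, unique, unknown or untested is made for them only; others in the source may bear on it.

Working notes on the series. In a functional assay on HepG2 cells (Homo sapiens) for cytotoxicity, read by MTT assay, with a stated time of 48 h (on this read-out lower numbers stand for stronger inhibition and higher numbers for weaker inhibition), compound 1 (`COc1ccc(/C=C2/S/C(=N/c3ccccc3)N(Cc3ccncc3)C2=O)cc1`) gives 19100 nM, compound 2 (`O=C1/C(=C\c2ccc(Cl)cc2)S/C(=N/c2ccccc2)N1Cc1ccncc1`) gives 28800 nM and compound 3 (`O=C1/C(=C\c2ccc(O)c(O)c2)S/C(=N/c2ccccc2)N1Cc1ccncc1`) gives 16200 nM. Compound 3 cannot be separated from compound 1 or compound 2 on these numbers, so it stands level with both within the scatter.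

The next structure is compound 4 (`COc1ccc(OC)c(/C=C2/S/C(=N/c3ccccc3)N(Cc3ccncc3)C2=O)c1`), with 2,5-dimethoxyphenyl in place of 3,4-dihydroxyphenyl on a double-bonded chain carbon bound to a double-bonded ring carbon.

Two measured steps change the group at this same place: a 1.2-fold lower number from compound 1 to compound 3 (0.07 log units; within the scatter) and a 1.8-fold lower number from compound 2 to compound 3 (0.25 log units; within the scatter). The remaining step, a 1.5-fold higher number from compound 1 to compound 2 (0.18 log units; within the scatter), also concerns the substituent on this aromatic ring. All three are small, and none leaves the scatter. Among the compounds with values here, no compound measured so far carries 2,5-dimethoxyphenyl, so the data offer no direct precedent for this group, and the range has to stay wider than these steps alone suggest.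

Within the data shown here, with compound 1 and compound 2 as the only guides, no step beyond the scatter is expected in this assay, and no direction is favoured with any confidence. The estimated step is a 1.2-fold higher number from compound 3 to compound 4 (0.09 log units; within the scatter). For compound 4 the estimated value is 20000 nM, with an expected range of 10000 nM to 40000 nM.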

Compound 4, half-maximal inhibitory concentration: 35800 nM
For compound 4 the middle estimate is 1.8-fold (0.25 log units) below the measured one; low and high end bracket the measured number.
By their numbers in this assay, from the lowest: compounds 3, 1, 2 and 4 (each within the scatter of the next, the first and the last beyond it).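

In this assay, within the data shown here, 2,5-dimethoxyphenyl in place of 3,4-dihydroxyphenyl gives a 2.2-fold higher number from compound 3 to compound 4 (0.34 log units; beyond the scatter) and is the first step to leave the scatter, so the group on this double-bonded chain carbon can move the number, if only modestly. The same group cannot be separated from the two singly substituted or chloro-bearing comparators, with a 1.2-fold higher number from compound 2 to compound 4 (0.09 log units; within the scatter) and a 1.9-fold higher number from compound 1 to compound 4 (0.27 log units; within the scatter) both remaining within the scatter, so only its gap to 3,4-dihydroxyphenyl is resolved. Nothing at hand explains that gap.

The change from compound 3 to compound 4 alters both the oxygen substituents and their pattern on the ring, and the hydrogen-bond donors leave with it, so these compounds cannot say which part of the change goes with the higher number; 3,4-dimethoxyphenyl would separate hydroxy from methoxy on the same pattern. Also open, from the compounds shown here alone, is whether a group of another kind at this place, such as an aminophenyl or a carboxyphenyl, would move the number further in either direction.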